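Cyclopentyl for ethyl at the ketone side chain

The compounds below may be only part of what the source reports. "The series", "measured", "known", "first", "only" and "open" are said of these compounds alone.

Two compounds measured in an assay on HEK293 cells for positive allosteric modulation of metabotropic glutamate receptor 2 (Rattus norvegicus), read by thallium flux, with a stated time of 2.5 min (on this read-out higher numbers stand for larger maximal responses and lower numbers for smaller maximal responses), frame this step. Compound 1, `COc1cc(C(=O)O)ccc1OCCCCOc1ccc(C(=O)CC(C)(C)C)c(O)c1C`, gives 98.6% in this assay. Compound 2, `CCCC(=O)c1ccc(OCCCCOc2ccc(C(=O)O)cc2C)c(C)c1O`, gives 79.3% in this assay, the lower of the two numbers, and the gap to compound 1 lies beyond the usual scatter. Among the measured compounds shown here, the two structures differ in more than one place, so no single step between them can be read off; only their two values can be compared.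

Compound 3, `Cc1cc(C(=O)O)ccc1OCCCCOc1ccc(C(=O)CC2CCCC2)c(O)c1C`, has not yet been measured in this assay. It differs from compound 2 in one place: cyclopentyl in place of ethyl on a saturated chain carbon bound to a carbonyl carbon. For the measured compounds named here, since no measured pair shows this change, its effect is open. A modest rise in maximal response is expected, though a step within the scatter or a small fall cannot be ruled out; the expected step is a number 8.7 percentage points higher from compound 2 to compound 3 (within the scatter). Compound 3 is therefore estimated at 88%, with a range from 68% to 104%.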

Compound 3, largest response reached (reported as percent of maximum), in percent of the reference or control that the assay uses: 84.6%
For compound 3 the middle estimate is 3.4 percentage points above the measured one, and the stated range covers the measured number.
By their numbers in this assay, from the lowest: compounds 2 and 3 (each within the scatter of the next); then compound 1.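

In this assay, cyclopentyl in place of ethyl on a saturated chain carbon bound to a carbonyl carbon gives a number 5.3 percentage points higher from compound 2 to compound 3 (within the scatter), the first single-place step available in this series. This place therefore takes a five-membered non-aromatic ring of carbon only, with three more heavy atoms than ethyl, and the read-out does not separate compound 3 from compound 2. Nothing measured here bears on the reason for this result.

The compounds shown leave open whether a cyclohexyl ring, a phenyl ring or an amine at this place would also stay within the scatter of compound 2 or give a step beyond it. They also leave open whether the same exchange would give a similar step on a different core.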